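Phenyl Added to a Bare Pyrazole Amidine

The source may report more compounds than this note shows. Statements on the series, on what has been measured and on what is new or still open speak of the compounds shown alone.

Among the compounds with values here, compound 1 `Cn1nc(-c2ccccc2)c2cc(C(=N)Nc3ccccc3)ncc21` is the one compound here with a number in a functional assay on MDA-MB-231 cells (Homo sapiens) for cytotoxicity, read by MTT assay, with a stated time of 72 h; on this read-out lower numbers stand for stronger inhibition and higher numbers for weaker inhibition: compound 1 gives 11100 nM. Compound 2 `N=C(Nc1ccccc1)c1cc2cn[nH]c2cn1` returns in this assay only a limit, > 50000 nM, which is the limit of > 50000 nM in this assay, at which 1 of the 2 values shown sits. Compound 2 therefore stands at the weak edge of what this assay resolves, with no number of its own.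

Compound 3 `N=C(Nc1ccccc1)c1cc2c(-c3ccccc3)n[nH]c2cn1` arises from compound 2 by phenyl in place of hydrogen on an aromatic carbon. Within the data shown here, compound 1 carries the same phenyl group but differs from compound 3 elsewhere, so no measured step isolates this change. In this assay compound 3 is expected to give 20000 nM, within 6000 nM to 60000 nM. The step of an at least 2.5-fold lower number from compound 2 to compound 3 (0.39 log units; beyond the scatter) is expected to run toward lower numbers, beyond the scatter, though compound 3 may still return only a limit.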

Compound 3, half-maximal inhibitory concentration: 11000 nM
Compound 3: the middle estimate sits 1.8-fold (0.26 log units) above what was measured, and the stated range covers the measured number.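

In this assay, phenyl in place of hydrogen on an aromatic carbon of the five-membered ring gives an at least 4.5-fold lower number from compound 2 to compound 3 (0.65 log units; beyond the scatter), so this position responds to the change and compound 3 carries a number of its own. Compound 2 has only a limit, so that step gives a bound on the effect of phenyl and not its full size: the limit of > 50000 nM in this assay, at which 1 of the 3 values shown sits. Hydrogen in place of methyl on an aromatic nitrogen gives a 1.0-fold lower number from compound 1 to compound 3 (0.00 log units; within the scatter), so with phenyl in place, that methyl makes no difference that this assay can resolve.

The compounds shown leave open whether an amine or a carboxylic acid on that same aromatic carbon would match phenyl. They also leave open whether a longer chain on the aromatic nitrogen would behave as methyl does.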